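Benzyl to 2-sulfanylethyl on the ring nitrogen of compound 3

A few compounds are considered here, and "the series" means these few. Any claim that something is new, unique, unknown or untested is made for them only; others in the source may bear on it.

Working notes on a small set of compounds sharing one core. Compound 1 `Nc1nc2ccc(CC(F)(F)F)cc2s1` and compound 2 `Nc1nc2ccc(OCC(F)(F)C(F)(F)F)cc2s1` carry a free amine on that core. In a functional assay on the whole organism with Rattus norvegicus as the target (on this read-out lower numbers stand for an effect already at smaller amounts and higher numbers for an effect only at larger amounts of compound), compound 1 gives 8 mg/kg. In this assay compound 2 gives 7.5 mg/kg. Compound 3 `N=c1sc2cc(OC(F)(F)F)ccc2n1Cc1ccccc1` has a benzyl group on the ring nitrogen and a trifluoromethoxy group on the core. In this assay, going by the values given here, compound 3 gives only a limit, > 10 mg/kg, so no number stands for it; it is the one value of the three that sits at the limit of > 10 mg/kg in this assay, at which 1 of the 3 values shown sits.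

Compound 4 `N=c1sc2cc(OC(F)(F)F)ccc2n1CCS` is the compound to be measured next. It differs from compound 3 in one place: sulfanylmethyl in place of phenyl on a saturated chain carbon bound to an aromatic nitrogen. Among the compounds with values here, because compound 3 is known only by > 10 mg/kg, no measured step involving the ring nitrogen substituent is available, and compounds 1 and 2 show only what their own values show for a free amine on the same core.

For compound 4 the expectation is a step that the limit leaves unreadable from compound 3 to compound 4, which is no change beyond the usual scatter. Compound 4 is therefore estimated at 12 mg/kg in this assay, with a range from 5 mg/kg to 30 mg/kg, and a real chance that the assay again reports only a limit.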

Compound 4, dose for half-maximal effect: 2 mg/kg
Compound 4: middle estimate off by 6.0-fold (0.78 log units), on the high side, and the stated range ends above it.
By their numbers in this assay, from the lowest: compound 4; then compounds 2 and 1 (each within the scatter of the next). At a limit, above all of these: compound 3.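

In this assay, going by these compounds alone, the substituent on the ring nitrogen now has a readable effect, which the earlier compounds could not give: the change from benzyl to 2-sulfanylethyl gives an at least 5.0-fold lower number from compound 3 to compound 4 (0.69 log units; beyond the scatter). The change takes away phenyl, a six-membered aromatic ring of carbon only, and brings in sulfanylmethyl, which has no ring and adds a hydrogen-bond donor and acceptor; this single step cannot separate those differences. Compound 3 is known only as a limit, > 10 mg/kg, and the step is a bound rather than a full size because of that limit: the limit of > 10 mg/kg in this assay, at which 1 of the 4 values shown sits.

Within the data shown here, compounds 1 and 2 carry a free amine and differ from compound 4 in more than one place, so no steps to them can be read. From the compounds shown here alone, whether the sulfur itself carries the step remains open, as does how a hydroxyl, an amine or a longer chain would read in place of sulfanylmethyl on a saturated chain carbon bound to an aromatic nitrogen.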